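A diacid side chain on the amide nitrogen

The compounds below may be only part of what the source reports. "The series", "measured", "known", "first", "only" and "open" are said of these compounds alone.

Measured in a functional assay on PC-3 cells (Homo sapiens) for antiproliferative activity, read by MTT assay, with a stated time of 24 h; a lower number here means a stronger inhibitor, a higher number a weaker inhibitor:
Compound 1 `CCn1c(C(=O)NCCC(=O)OC)ccc1C(CC)(CC)c1ccc(OCS(=O)(=O)c2ccccc2)c(C)c1`: 40400 nM
Compound 2 `CCn1c(C(=O)NC2(C(=O)O)CC2)ccc1C(CC)(CC)c1ccc(OCS(=O)(=O)c2ccccc2)c(C)c1`: 26300 nM

Among the compounds with values here, compound 2, at 26300 nM, cannot be ranked against compound 1, the only other compound measured. Compound 3 `CCn1c(C(=O)N[C@@H](CC(=O)O)C(=O)O)ccc1C(CC)(CC)c1ccc(OCS(=O)(=O)c2ccccc2)c(C)c1` has not yet been measured. It carries 1,2-dicarboxyethyl in place of the 1-carboxycyclopropyl of compound 2, on the same amide-type nitrogen: 1,2-dicarboxyethyl in place of 1-carboxycyclopropyl on an amide-type nitrogen. Within the data shown here, only one measured step bears on this change, a 1.5-fold lower number from compound 1 to compound 2 (0.19 log units; within the scatter), and it too alters the group on that nitrogen. Among the measured compounds shown here, no measured compound carries 1,2-dicarboxyethyl, so the data point in neither direction. For the measured compounds named here, with that small step as the only guide, no step beyond the scatter is expected in this assay. The estimated step is a 1.1-fold higher number from compound 2 to compound 3 (0.06 log units; within the scatter). For compound 3 the expected value is 30000 nM, with an estimated range of 13000 nM to 70000 nM.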

Compound 3, half-maximal inhibitory concentration: > 50000 nM
Compound 3: only a limit was reported; the forecaster's own chance of this, stated with the estimate: 15%; middle value at least 1.6-fold (0.22 log units) from the limit.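

In this assay compound 3 gives > 50000 nM, which is a limit and not a number: the limit of > 50000 nM in this assay, at which 1 of the 3 values shown sits.

Read against the two earlier side chains on the amide-type nitrogen, this gives an at least 1.9-fold higher number from compound 2 to compound 3 (0.27 log units; that floor lies within the scatter) and an at least 1.2-fold higher number from compound 1 to compound 3 (0.09 log units; that floor lies within the scatter); both floors lie within the scatter, so the true size of either step cannot be told. What is new is the direction: unlike the earlier step, which stayed within the scatter and left the direction unsettled, the change to 1,2-dicarboxyethyl gives no lower number than either earlier group.

How far the true value of compound 3 lies past its limit stays open, and the compounds shown do not separate the loss of the cyclopropane ring from the entry of the second carboxylic acid. Going by these compounds, whether an amine or a longer chain ending in a carboxylic acid on this nitrogen would give a lower number also remains open.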